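Swapping the pyridine on a piperazine amide

The source may hold more compounds than are shown below. What is called first, only, known or untested is meant among the compounds shown, and "the series" means these compounds.

Measured so far:
- compound 1, `Cc1cc(F)cnc1N1CCN(C(=O)CCCc2cccc3ncc(CO)cc23)[C@@H](C)C1`, gives 1% in an ADME assay on microsomes from liver (Rattus norvegicus) for metabolic stability, read by LC-MS, with a stated time of 15 min, tested at 1 uM; on this read-out higher numbers stand for a more stable compound and lower numbers for a less stable compound
- compound 2, `Cc1cc(F)cnc1N1CCN(C(=O)CCS(=O)(=O)c2cccc3ncsc23)[C@@H](C)C1`, gives 9.6% in this assay
- compound 3, `O=C(CCS(=O)(=O)c1cccc2ncsc12)N1CCN(c2ccnc(C(F)(F)F)c2)CC1`, gives "not determined" (no result reported) in this assay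

Compounds 1 and 2 both leave little of the compound behind after the incubation, and the two values lie within the usual scatter of each other, so no order can be read between them. Compound 3 stands nowhere on the numbers shown: its entry reads "not determined" (no result reported), so its own position in this assay is unknown.

Compound 4, `O=C(CCS(=O)(=O)c1cccc2ncsc12)N1CCN(c2ccc(Cl)cn2)CC1`, differs from compound 3 in one place: 5-chloropyridin-2-yl in place of 2-(trifluoromethyl)pyridin-4-yl on an amine nitrogen in a ring. Both compounds share the same sulfone-linked core with compound 2. Among the measured compounds shown here, with no measured step from compound 3, no direction or size can be taken from the data; the expectation for compound 4 rests on the related compounds, and since compound 2 gives 9.6% the new compound is expected to sit in the same low region.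

Compound 4 is estimated at 10%, within a range from 2% to 35%.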

Compound 4, percent of the compound remaining: 31%
Estimate against measurement, compound 4: 21 percentage points below; low and high end bracket the measured number.
By their numbers in this assay, from the lowest: compounds 1 and 2 (each within the scatter of the next); then compound 4.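

In this assay, among the compounds shown here, compound 3 has no number, so no step from it to compound 4 can be read. No measured evidence here accounts for the result of compound 4. Still open, going by these compounds, is how 5-chloropyridin-2-yl compares with 2-(trifluoromethyl)pyridin-4-yl on the shared core.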